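The source may report more compounds than this note shows. Statements on the series, on what has been measured and on what is new or still open speak of the compounds shown alone.

Working notes on the series. Among the compounds with values here, in a toxicity assay on the whole organism (J774 cells) for cytotoxicity, with Mus musculus as the target, read by MTT assay, with a stated time of 24 h, tested at 30 uM (a higher number here means a weaker effect of the compound at the concentration tested, a lower number a stronger effect), compound 3, `CCCCCCCCCO[C@@H]1[C@@H](N)[C@@H](OCC(O)CNCCO)O[C@H](CN)[C@H]1OCCCCCCCCC`, gives 10.1%, the second highest of three numbers measured so far. Its nearest neighbour is compound 1, `CCCCCCCCCO[C@@H]1[C@@H](N)[C@@H](OCC(O)CNCCCO)O[C@H](CN)[C@H]1OCCCCCCCCC`, which in this assay gives 13.7%; the step of a number 3.6 percentage points lower from compound 1 to compound 3 (within the scatter). Furthest from it is compound 2, `CCCCCCCCCO[C@@H]1[C@@H](N)[C@@H](OC[C@H](O)CN=[N+]=[N-])O[C@H](CN)[C@H]1OCCCCCCCCC`, which gives 5.9%; the step of a number 4.2 percentage points higher from compound 2 to compound 3 (within the scatter). The remaining pair is covered by a number 7.8 percentage points lower from compound 1 to compound 2 (within the scatter). Within the data shown here, all three numbers are low, so all three compounds act strongly at the concentration used, and no step among them separates from the scatter.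

Compound 4 is `CCCCCCCCCO[C@@H]1[C@@H](N)[C@@H](OC[C@@H](O)CN)O[C@H](CN)[C@H]1OCCCCCCCCC`. The change from compound 3 is 2-amino-1-hydroxyethyl in place of 1-hydroxy-2-((2-hydroxyethyl)amino)ethyl on a saturated chain carbon bound to an oxygen on a saturated carbon.

Two measured steps alter the same position, the substituent on the saturated chain carbon bound to an oxygen on a saturated carbon: a number 7.8 percentage points lower from compound 1 to compound 2 (within the scatter) and a number 4.2 percentage points higher from compound 2 to compound 3 (within the scatter), both within the scatter. Those changes swap groups at least as different from one another as the present one, and neither moved the read-out beyond the scatter. Among the measured compounds shown here, no step bearing on this position points in a direction, so no step beyond the scatter is expected for compound 4 in this assay.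

The expected step is a number 1.1 percentage points lower from compound 3 to compound 4 (within the scatter). Compound 4 is therefore estimated at 9%, with a range from 2% to 18%.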

Compound 4, a percentage reported as activity, at one concentration (the size of the read-out at that concentration, not a potency): 7.2%
Compound 4: the middle estimate sits 1.8 percentage points above what was measured; the measured number falls inside the stated range.
By their numbers in this assay, from the lowest: compounds 2, 4, 3 and 1 (each within the scatter of the next).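

Replacing the substituent on the saturated chain carbon with 2-amino-1-hydroxyethyl, which carries no hydroxyalkyl group on its nitrogen, leaves this assay without a step beyond the scatter: a number 2.9 percentage points lower from compound 3 to compound 4 (within the scatter), a number 1.3 percentage points higher from compound 2 to compound 4 (within the scatter) and a number 6.5 percentage points lower from compound 1 to compound 4 (within the scatter). The earlier compounds shown here showed this only for the azido group and the two hydroxyalkylamino groups; the unsubstituted amino group now joins them, so none of the four groups at this position separates from the others, and the low numbers persist without the 2-hydroxyethyl or 3-hydroxypropyl group on the nitrogen. Compound 4 also has a defined stereocentre in the entering group, which compound 3 lacks in the leaving group, so this step carries both differences, and no evidence here accounts for the flat read-out.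

From the compounds shown here alone, whether a carboxylic acid, a longer alkyl chain on the nitrogen or the opposite stereoisomer of 2-amino-1-hydroxyethyl would move the read-out beyond the scatter remains open. A read-out at one concentration also leaves open how far these compounds differ in potency at lower concentrations.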